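This account rests on a few compounds, and the source may have more. Where it says the series, first, only, none or still open, it means among the compounds named here.

Measured so far in a functional assay on HCT-116 cells (Homo sapiens) for antiproliferative activity, read by MTT assay, with a stated time of 24 h; on this read-out higher numbers stand for weaker inhibition and lower numbers for stronger inhibition:
compound 1 `COc1cc(OC)c(-c2coc3cc(OCC=C(C)C)ccc3c2=O)cc1OC` gives 680 nM
compound 2 `C#CCOc1ccc2c(=O)c(-c3cc(OC)c(OC)cc3OC)coc2c1` gives 8050 nM
compound 3 `COc1ccc2c(=O)c(-c3cc(OC)c(OC)cc3OC)coc2c1` gives 9170 nM

Compound 1 stands lowest of the three numbers in this assay; both steps away from it are beyond the scatter, so it is the strongest inhibitor in this set. The step of a 12-fold higher number from compound 1 to compound 2 (1.07 log units; beyond the scatter) and the step of a 13-fold higher number from compound 1 to compound 3 (1.13 log units; beyond the scatter) are both large and both go in the same direction, while compound 2 and compound 3 sit within the scatter of each other, as a 1.1-fold higher number from compound 2 to compound 3 (0.06 log units; within the scatter) shows. Every change at this position that has been measured, then, took the 2-methylprop-1-en-1-yl group away and raised the number.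

Compound 4 `COc1cc(OC)c(-c2coc3cc(OCC(=O)c4cccc(C(F)(F)F)c4)ccc3c2=O)cc1OC` is not yet measured. It differs from compound 1 by (3-(trifluoromethyl)phenyl)carbonyl in place of 2-methylprop-1-en-1-yl on a saturated chain carbon bound to an oxygen on an aromatic ring. The measured steps bear on it only in so far as they show the 2-methylprop-1-en-1-yl group matters at this place; nothing measured shows what a larger aromatic replacement does there. For compound 4 a higher number than for compound 1 is expected in this assay, a step of about a 4.4-fold higher number from compound 1 to compound 4 (0.64 log units; beyond the scatter), with wide uncertainty. The estimate for compound 4 is 3000 nM, in the range 500 nM to 15000 nM.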

Compound 4, half-maximal inhibitory concentration: > 10000 nM
Compound 4 was reported as a limit; the forecaster's own chance of this, stated with the estimate: 5%; at least 3.3-fold (0.52 log units) between middle value and limit.
By their numbers in this assay, from the lowest: compound 1; then compounds 2 and 3 (each within the scatter of the next). At a limit, above all of these: compound 4.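

Compound 4 is reported in this assay only as a limit: the limit of > 10000 nM in this assay, at which 1 of the 4 values shown sits.

With (3-(trifluoromethyl)phenyl)carbonyl in place of 2-methylprop-1-en-1-yl on a saturated chain carbon bound to an oxygen on an aromatic ring, the series shows an at least 14-fold higher number from compound 1 to compound 4 (1.16 log units; beyond the scatter) as a large step, so the earlier finding now extends beyond the ethynyl and hydrogen replacements to one with an aromatic ring, and compound 1 remains the strongest inhibitor of the four. Both an at least 1.2-fold higher number from compound 2 to compound 4 (0.09 log units; that floor lies within the scatter) and an at least 1.0-fold higher number from compound 3 to compound 4 (0.03 log units; that floor lies within the scatter) stop at a floor that lies within the scatter, so neither can be read as a difference.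

Open, from the compounds shown here alone, is which part of the entering group goes with the higher number: the carbonyl, the aromatic ring or the trifluoromethyl. Also open, going by these compounds, is whether a saturated 3-methylbutyl chain, a longer prenyl-like chain or a plain benzyl group would stay near compound 1.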